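The compounds below may be only part of what the source reports. "The series", "measured", "known", "first", "only" and "open" are said of these compounds alone.

Compound 2 `CC(C)c1noc(N2CCC(CCCNc3ccc4c(c3)OCC4=O)CC2)n1` has the lowest of the two numbers measured in a functional assay on CHO-K1 cells for agonist activity at Glucose-dependent insulinotropic receptor (Homo sapiens), read by HTRF and cAMP accumulation, with a stated time of 30 min; on this read-out lower numbers stand for an effect already at smaller amounts and higher numbers for an effect only at larger amounts of compound: compound 2 gives 73 nM, and compound 1 `CCc1cnc(N2CCC(CCCNc3ccc4c(c3)OCC4=O)CC2)nc1` gives 117 nM, a gap that stays within the scatter, as a 1.6-fold lower number from compound 1 to compound 2 (0.20 log units; within the scatter) shows. Compound 3 `CC(C)c1nnc(N2CCC(CCCNc3ccc4c(c3)OCC4=O)CC2)o1` differs from compound 2 only in the ring attached to the amine nitrogen: 5-isopropyl-1,3,4-oxadiazol-2-yl in place of 3-isopropyl-1,2,4-oxadiazol-5-yl on an amine nitrogen in a ring. Within the data shown here, the one measured step swaps a quite different ring onto this nitrogen and still barely moves the number, so a rearrangement of the same atoms is expected to give no step beyond the scatter in this assay. Compound 3 is therefore estimated at 90 nM, between 35 nM and 250 nM, a change of a 1.2-fold higher number from compound 2 to compound 3 (0.09 log units; within the scatter).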

Compound 3, half-maximal effective concentration: 704 nM
Compound 3: middle estimate off by 7.8-fold (0.89 log units), on the low side, and the stated range ends below it.
By their numbers in this assay, from the lowest: compounds 2 and 1 (each within the scatter of the next); then compound 3.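

On the amine nitrogen of the six-membered ring, the arrangement of atoms within the five-membered ring matters: the two oxadiazolyl groups have the same atom and hydrogen-bond counts, yet the swap gives a clear loss (a 9.6-fold higher number from compound 2 to compound 3 (0.98 log units; beyond the scatter)). Compound 3 also falls clearly behind the pyrimidine-bearing compound (a 6.0-fold higher number from compound 1 to compound 3 (0.78 log units; beyond the scatter)), so here an isomer swap counts for more than the larger ring change between compound 1 and compound 2. Nothing available explains this gap. From the compounds shown here alone, it remains open whether the gap between the two oxadiazole arrangements persists with cyclopropyl or trifluoromethyl in place of isopropyl.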